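From a branched to a linear chain on sulfur

The compounds below may be only part of what the source reports. "The series", "measured", "known", "first", "only" and "open" are said of these compounds alone.

Compound 1 `O=[N+]([O-])c1ccc2c(c1)CN(c1ncnc3c1nc1n3[C@@H]3O[C@H](CO1)[C@@H](O)[C@H]3O)CC2` gives 331 nM in an assay on isolated protein for binding affinity to Equilibrative nucleoside transporter 1 (Homo sapiens); a higher number here means a weaker inhibitor, a lower number a stronger inhibitor.
Compound 2 `OC[C@H]1O[C@@H](n2cnc3c(NCc4ccco4)ncnc32)[C@H](O)[C@@H]1O` gives 36300 nM in this assay.
Compound 3 `CC(C)(Sc1ncnc2c1ncn2[C@@H]1O[C@H](CO)[C@@H](O)[C@H]1O)c1ccccc1` gives 21400 nM in this assay.

Compound 3 holds the second highest of the three numbers. Its nearest neighbour is compound 2, whose number lies within the scatter of it, while compound 1 lies well lower, beyond the scatter. Compound 4 `OC[C@H]1O[C@@H](n2cnc3c(SCCCc4ccccc4)ncnc32)[C@H](O)[C@@H]1O` differs from compound 3 in one place: 3-phenylpropyl in place of 1-methyl-1-phenylethyl on a sulfur. Going by the values given here, no measured pair shows a change of this kind, so its size is uncertain. The step of a 1.8-fold lower number from compound 3 to compound 4 (0.25 log units; within the scatter) is expected to be modest, leaning toward a lower number but possibly not beyond the scatter. For compound 4 the expected value in this assay is 12000 nM, with a range from 3000 nM to 50000 nM.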

Compound 4, half-maximal inhibitory concentration: 1350 nM
For compound 4 the middle estimate is 8.9-fold (0.95 log units) above the measured one, and the stated range ends above it.
By their numbers in this assay, from the lowest: compound 1; then compound 4; then compounds 3 and 2 (each within the scatter of the next).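

On the sulfur, the arrangement of the same carbon atoms matters in this assay: 3-phenylpropyl in place of 1-methyl-1-phenylethyl gives a 16-fold lower number from compound 3 to compound 4 (1.20 log units; beyond the scatter), although both groups have the same heavy-atom count and one six-membered aromatic ring of carbon only. This position therefore responds strongly to the shape of the chain, not merely to its composition. Nothing available explains the size of this step. As far as these compounds go, whether a shorter or longer chain on the sulfur, or a chain ending in an amine or a carboxylic acid, would preserve this gain remains open.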